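A few compounds are considered here, and "the series" means these few. Any claim that something is new, unique, unknown or untested is made for them only; others in the source may bear on it.

Measured compounds in a physicochemical assay for solubility, measured as kinetic solubility; a lower number here means a less soluble compound, a higher number a more soluble compound:
compound 1 `CN1CC2(C1)CN(c1ccc(OCc3ccccc3)c(C(=O)Nc3ccnnc3)c1)C2` gives 198000 nM;
compound 2 `O=C(Nc1ccnnc1)c1cc(N2CCC(F)CC2)ccc1OCc1ccccc1` gives 20000 nM;
compound 3 `O=C(Nc1ccnnc1)c1cc(N2CCC(CO)CC2)ccc1OCc1ccccc1` gives 323000 nM.

Compound 1 stands second highest of the three numbers. Its nearest neighbour is compound 3, a step of a 1.6-fold higher number from compound 1 to compound 3 (0.21 log units; within the scatter), which is within the scatter; its furthest is compound 2, a step of a 9.9-fold lower number from compound 1 to compound 2 (1.00 log units; beyond the scatter), which is beyond it. The two six-membered ring replacements thus bracket compound 1: one leaves the number essentially unchanged, the other pulls it down by a modest amount, and the gap between those two, a 16-fold higher number from compound 2 to compound 3 (1.21 log units; beyond the scatter), is large.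

Compound 4 `O=C(Nc1ccnnc1)c1cc(N2C[C@H]3COC[C@H]3C2)ccc1OCc1ccccc1` is not yet measured. Its change from compound 1 is a group of 8 heavy atoms (6 carbon, 1 nitrogen, 1 oxygen; 2 five-membered non-aromatic rings with 1 hetero atom each) in place of a group of 8 heavy atoms (6 carbon, 2 nitrogen; 2 four-membered non-aromatic rings with 1 hetero atom each), on an aromatic carbon. The incoming group keeps the same atom count and the same number of acceptors, but one nitrogen of the leaving group is exchanged for an oxygen, and the two four-membered rings become two five-membered rings with two defined stereocentres. For the measured compounds named here, no measured step covers this exact exchange; the closest reference is compound 2, where a group with one nitrogen and no second basic centre gave the lower number. A step downward from compound 1, smaller than that to compound 2, is therefore expected: a 2.8-fold lower number from compound 1 to compound 4 (0.45 log units; beyond the scatter). Compound 4 is estimated at 70000 nM, with a range of 25000 nM to 200000 nM.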

Compound 4, solubility: 57000 nM
Compound 4: middle estimate off by 1.2-fold (0.09 log units), on the high side; the measured number falls inside the stated range.
By their numbers in this assay, from the lowest: compound 2; then compound 4; then compounds 1 and 3 (each within the scatter of the next).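

In this assay, the group meta to the (pyridazin-4-yl)carbamoyl group and para to the benzyloxy group can shift the number even when heavy atom, donor and acceptor counts stay the same, as shown by a 3.5-fold lower number from compound 1 to compound 4 (0.54 log units; beyond the scatter). Element make-up does not fix the number either: the groups of compound 3 and compound 4 both hold 6 carbon, 1 nitrogen and 1 oxygen, yet the data show a 5.7-fold lower number from compound 3 to compound 4 (0.75 log units; beyond the scatter), while a 2.9-fold higher number from compound 2 to compound 4 (0.45 log units; beyond the scatter) keeps compound 4 clear of the fluoro compound, so the two five-membered rings give an intermediate result among these four groups. No measurement available here accounts for these differences.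

The compounds shown leave open where a primary amine or a carboxylic acid in place of the hydroxymethyl on the six-membered ring would fall in this range. They also leave open whether the number of compound 4 depends on its two defined stereocentres, and whether these steps hold on a core with a different group in place of the benzyloxy group.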